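Inverting one stereocentre in a urea series

The compounds below may be only part of what the source reports. "The series", "measured", "known", "first", "only" and "open" are said of these compounds alone.

Three ureas have been measured in an ADME assay on the whole organism with Oryza sativa as the target, tested at 1 uM; on this read-out higher numbers stand for a weaker effect at the one concentration tested and lower numbers for a stronger effect. Compound 1 `CCc1ccccc1NC(=O)N[C@@H](C)c1ccccc1` gives 100% in this assay. Compound 2 `C[C@H](NC(=O)Nc1ccccc1Br)c1ccccc1` gives 99%. Compound 3 `C[C@@H](NC(=O)Nc1ccccc1I)c1ccccc1` gives 100%, level with compound 1 at the digits shown, so these two share the highest numbers of the three, while the gap to compound 2 lies within the usual scatter, so no order among the three can be claimed.

The unmeasured compound 4 `C[C@H](NC(=O)Nc1ccccc1I)c1ccccc1` differs from compound 3 only in configuration: the two compounds have the same atoms and bonds and differ only in configuration as drawn: 1 of 1 stereo elements differ; a stereocentre at a saturated chain carbon is drawn R in compound 3 and S in compound 4. Within the data shown here, the one measured step, a number 1 percentage points lower from compound 1 to compound 2 (within the scatter), exchanges a substituent on an aromatic carbon and therefore says nothing directly about a change of configuration; it does show, together with compound 3, that all three measured compounds sit near the top of the read-out whatever the substituent. Among the measured compounds shown here, no step in this assay compares two configurations of the same atoms, so the expectation for compound 4 rests on the closeness of all three numbers.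

Compound 4 is therefore expected to show a number 1 percentage points lower from compound 3 to compound 4 (within the scatter), a change not beyond the scatter. The estimate for compound 4 in this assay is 99%, with a range from 90% to 100%.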

Compound 4, a percentage reported as activity, at one concentration (the size of the read-out at that concentration, not a potency): 100%
Beside the measured number, compound 4's estimate is 1 percentage points below it, within the range that was stated.
By their numbers in this assay, from the lowest: compounds 2, 1, 3 and 4 (each within the scatter of the next).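

This pair is the first in the series to test configuration alone, and inverting the stereocentre at the saturated chain carbon in this assay gives no change at the digits printed from compound 3 to compound 4 (within the scatter), so at this position and with the iodo group, the drawn configuration does not separate the two numbers: the fact that compounds 3 and 4 differ only in the configuration as drawn

Compound 4 also extends the substituent comparison within its own configuration, with iodo in place of bromo giving a number 1 percentage points higher from compound 2 to compound 4 (within the scatter) and iodo in place of ethyl giving no change at the digits printed from compound 1 to compound 4 (within the scatter). Neither of these exchanges on the aromatic carbon moves the number beyond the scatter, so these steps give no sign that the choice among ethyl, bromo and iodo matters in this read-out.

Still open, going by these compounds, is whether inverting this stereocentre would change the number in a compound that lies well away from these values in this assay. The compounds shown also leave open what an amine or a carboxylic acid on the aromatic carbon would give, and whether the two configurations would stay level with either group in place.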